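A few compounds are considered here, and "the series" means these few. Any claim that something is new, unique, unknown or untested is made for them only; others in the source may bear on it.

Compound 1, `COc1ccc(-c2cc(/C=C/C(=O)c3ccc(N)cc3)[nH]n2)cc1`: -60%
Compound 2, `COc1cc(-c2cc(/C=C/C(=O)c3ccc(N)cc3)[nH]n2)cc(OC)c1OC`: -3%
Compound 3, `COc1ccc(C(=O)/C=C/c2cc(-c3cc(OC)c(OC)c(OC)c3)n[nH]2)cc1`: 1%

All three were tested in a functional assay on K562 cells (Homo sapiens) for cytotoxicity, read by sulforhodamine B assay, with a stated time of 48 h, tested at 100 uM; on this read-out lower numbers stand for a stronger effect and higher numbers for a weaker effect at the one concentration tested. On these numbers compound 2 stands second highest of the three. Its nearest neighbour is compound 3, reached by a number 4 percentage points higher from compound 2 to compound 3 (within the scatter), and its furthest is compound 1, which lies far lower, beyond the usual scatter.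

Compound 4, `COc1ccc(-c2cc(/C=C/C(=O)c3ccc(N)cc3)[nH]n2)cc1OC`, has not yet been measured. It differs from compound 2 in one place: hydrogen in place of methoxy on an aromatic carbon.

Going by the values given here, the only measured single step, a number 4 percentage points higher from compound 2 to compound 3 (within the scatter), exchanges a different group on a different ring and so says little about removing a methoxy here. Compound 1 carries methoxy on the corresponding ring in a sparser pattern than compound 2, and the two are not a single step apart, so only their values can be compared: compound 1 gives -60%, while compound 2 gives -3%. Compound 4 sits between those two patterns, so it is expected to fall between their values, though with wide uncertainty. Compound 4 is estimated at -30%, with a range from -65% to 5%. This corresponds to an expected step of a number 27 percentage points lower from compound 2 to compound 4 (beyond the scatter), towards the lower, stronger side.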

Compound 4, a percentage reported as activity, at one concentration (the size of the read-out at that concentration, not a potency): -3%
The estimate for compound 4 lay 27 percentage points below the measured number; measured number inside the range.
By their numbers in this assay, from the lowest: compound 1; then compounds 2, 4 and 3 (each within the scatter of the next).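

In this assay, replacing one methoxy of the fuller pattern with hydrogen, at the place ortho to a methoxy group and meta to a large group, gives no change at the digits printed from compound 2 to compound 4 (within the scatter), so this particular methoxy can go with no visible consequence on this read-out. Compound 4 also links compound 1 and compound 2, which lie more than one change apart, and the other methoxy change gives a number 57 percentage points higher from compound 1 to compound 4 (beyond the scatter), so the whole gap between compound 1 and compound 2 sits at that one methoxy and none of it at the position just tested. Nothing available explains why one methoxy change matters so much and the other does not.

Hydrogen and methoxy are the only groups seen at the position tested here, so the effect of a hydroxy group, a fluorine atom or a longer ether such as ethoxy remains open. From the compounds shown here alone, it is also open whether the large step seen with the amino-bearing compounds would survive with methoxy in place of that amino group on the other ring, as in compound 3.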